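Halogen swap on a five-membered ring of an alkynyl nucleoside

This account rests on a few compounds, and the source may have more. Where it says the series, first, only, none or still open, it means among the compounds named here.

Measured so far:
- compound 1, `C#C[C@@]1(O)[C@@H](CO)O[C@@H](n2cnc3c(-c4ccc(Cl)cc4)ncnc32)[C@@H]1O`: 225000 nM
- compound 2, `C#C[C@@]1(O)[C@@H](CO)O[C@@H](n2cc(Cl)c3c(N)ncnc32)[C@@H]1O`: 14 nM

Of the compounds shown here, two have been measured in a functional assay on L1210 cells (Mus musculus) for antiproliferative activity, read by cell counting, with a stated time of 48 h; a lower number here means a stronger inhibitor, a higher number a weaker inhibitor. Compound 1 gives 225000 nM, while compound 2 gives 14 nM. Of the two numbers, compound 2 holds the lower one, and the gap between compound 2 and compound 1 lies well beyond the scatter of the assay. Within the data shown here, the two structures differ in more than one place, so no single step between them is drawn here; their two values are simply set side by side.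

The next compound, compound 3, `C#C[C@@]1(O)[C@@H](CO)O[C@@H](n2cc(I)c3c(N)ncnc32)[C@@H]1O`, departs from compound 2 in one place only: iodo in place of chloro on an aromatic carbon. Among the measured compounds shown here, no measured pair shows the effect of such a change in this assay. With nothing else to go on, the step in this assay is expected to stay within the scatter of repeated measurements, with no clear direction: a 1.2-fold lower number from compound 2 to compound 3 (0.07 log units; within the scatter) is the estimated step. In this assay compound 3 is therefore expected to give about 12 nM, within a range from 3 nM to 50 nM.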

Compound 3, half-maximal inhibitory concentration: 56 nM
The estimate for compound 3 lay 4.7-fold (0.67 log units) below the measured number; measured number outside the range, above it.
By their numbers in this assay, from the lowest: compound 2; then compound 3; then compound 1.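

This position on the five-membered aromatic ring with 1 nitrogen, two ring bonds from the ring nitrogen, turns out not to be indifferent to which halogen it carries: in this assay, iodo in place of chloro gives a 4.0-fold higher number from compound 2 to compound 3 (0.60 log units; beyond the scatter), a modest step but one that a single heavy atom exchanged for a single heavy atom is enough to produce. The change adds no ring, no hydrogen-bond donor or acceptor and no net charge, and compound 3 still gives 56 nM in this test, so the iodo group is tolerated here, although chloro gives the lower number of the two. Among these compounds, nothing measured so far accounts for the difference between the two halogens.

Going by these compounds, with only chloro and iodo seen on this carbon, the pair gives a single step and no trend, so it remains open how bromo, fluoro, a methyl group or a nitrile would compare with compound 2. On these data alone, it is also open whether the same exchange would carry the same step on a different core.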